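Methyl added to a benzamide: will cytotoxicity stay low?

The source may hold more compounds than are shown below. What is called first, only, known or untested is meant among the compounds shown, and "the series" means these compounds.

Measured so far:
- Compound 1, `O=C(Nc1ncc(Cc2ccc(F)cc2)s1)C1CCCCC1`: > 50000 nM
- Compound 2, `O=C(Nc1ncc(Cc2ccc(F)cc2)s1)c1ccccc1`: "not toxic" (no number reported)

Both compounds share one core, an amide fixed to a sulfur-containing ring that carries a fluorinated benzyl arm. In an ADME assay on HepG2 2.2.15 cells (Homo sapiens) for cytotoxicity (a higher number here means that more compound is tolerated, a lower number that less compound is tolerated), compound 1 reaches only a limit, > 50000 nM, which is not a number but the edge of the measurement. The same holds for (the limit of > 50000 nM in this assay, at which 1 of the 2 values shown sits). In this assay compound 2 is recorded merely as "not toxic" (no number reported), with no number behind it, so where compound 2 stands can only be said in words: no cytotoxicity was seen.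

Compound 3, `Cc1ccc(C(=O)Nc2ncc(Cc3ccc(F)cc3)s2)cc1`, is yet to be tested in this assay. Its difference from compound 2 is small, (methyl in place of hydrogen on an aromatic carbon). For the measured compounds named here, no measured step between any two compounds exists here, so the size of this step cannot be read from earlier pairs. Given that compound 2 showed no toxicity, the expectation is that compound 3 changes little, if anything, beyond the usual scatter, and most likely again reaches only a limit. The estimate for compound 3 in this assay is therefore 50000 nM, within a range from 20000 nM to 100000 nM.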

Compound 3, half-maximal cytotoxic concentration: "not toxic" (no number reported)
For compound 3 the study gives words and no number, and the estimate cannot be compared.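

For the compounds shown here, compound 2 and compound 3 are both recorded in this assay only in words, as not toxic, so no step from one to the other can be read. The only other entry, for compound 1, is a limit: the limit of > 50000 nM in this assay, at which 1 of the 3 values shown sits.

The compounds shown leave open at what concentration, if any, compound 2 or compound 3 would harm these cells.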